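Methoxy for Methyl on a Pyridine-Bearing Oxazole Ketone

A few compounds are considered here, and "the series" means these few. Any claim that something is new, unique, unknown or untested is made for them only; others in the source may bear on it.

Three compounds share a ketone tail and were tested in an assay on HEK-293T cells for inhibition of diacylglycerol lipase-alpha (Homo sapiens), read by colorimetric assay; a higher number here means a weaker inhibitor, a lower number a stronger inhibitor. Compound 1 `COc1coc(C(=O)CCCCCCc2ccccc2)n1` gives > 10000 nM, which is a limit of the assay and not a number. Compound 2 `Cc1coc(C(=O)CCCCCCc2ccccc2)n1` gives > 10000 nM, also a limit. Compound 3 `Cc1ccc(-c2cnc(C(=O)CCCCCCc3ccccc3)o2)nc1` gives > 10000 nM, again a limit. The change from compound 2 to compound 1 is methoxy in place of methyl on an aromatic carbon, and its step that the two limits leave unreadable from compound 2 to compound 1 cannot be read because of the limit of > 10000 nM in this assay, at which 3 of the 3 values shown sit. The difference between the cores of compound 2 and compound 3 is not broken down here. Compound 4 `COc1ccc(-c2cnc(C(=O)CCCCCCc3ccccc3)o2)nc1` differs from compound 3 by methoxy in place of methyl on an aromatic carbon, the same kind of change, but here the place is on a six-membered aromatic ring with 1 nitrogen, two atoms from the ring nitrogen, para to a large group. With all three values at the limit, the step that the limit leaves unreadable from compound 3 to compound 4 is only an estimate, and compound 4 is expected to give about 20000 nM in this assay, most likely again reported as a limit.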

Compound 4, half-maximal inhibitory concentration: > 10000 nM
Compound 4 was reported as a limit; the forecaster's own chance of this, stated with the estimate: 85%; the middle value is on the limit's open side.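

No step can be read between compound 3 and compound 4, because both values are limits and not numbers: the limit of > 10000 nM in this assay, at which 4 of the 4 values shown sit.

The compounds shown leave open how strongly each one inhibits the enzyme, and whether methoxy in place of methyl changes that inhibition at all.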